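The source may hold more compounds than are shown below. What is called first, only, known or untested is meant among the compounds shown, and "the series" means these compounds.

The measured compounds in this study:
compound 1, `CCCc1c(COc2ccc(C(=O)Cc3nnn[nH]3)cc2)ccc(C(C)=O)c1O`, 7.71
compound 2, `CCCc1c(COc2ccc(C(=O)CCCc3nnn[nH]3)cc2)ccc(C(C)=O)c1O`, 7.67

In a functional assay on ileum (Cavia porcellus) with cysteinyl leukotriene receptor (Homo sapiens) as the target (a higher number here means a more potent compound, by a factor of ten per unit of this negative logarithm, a lower number a less potent compound), compound 1 gives 7.71 and compound 2 gives 7.67. Compound 2 holds the lowest of the two numbers, with compound 1 as its nearest neighbour; the step of a number 0.04 log units lower from compound 1 to compound 2 (within the scatter) lies within the scatter, so the two are not ordered against each other.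

Compound 3, `CCCc1c(COc2ccc(C(=O)CC(C)(C)CC(=O)O)cc2)ccc(C(C)=O)c1O`, differs from compound 2 in one place: 1-(carboxymethyl)-1-methylethyl in place of 2-(1H-tetrazol-5-yl)ethyl on a saturated chain carbon bound to a carbonyl carbon. Among the measured compounds shown here, no measured step covers an exchange of this kind; the single step seen so far, which only lengthened the chain between the carbonyl and the tetrazole, changed nothing beyond the scatter. The estimate for compound 3 therefore rests on a weak basis, and the expected step of a number 0.37 log units lower from compound 2 to compound 3 (beyond the scatter) is a modest one, downward. Compound 3 is expected to give 7.3, in a range from 6.6 to 8.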

Compound 3, negative logarithm of the antagonist equilibrium constant: 7.73
The estimate for compound 3 lay 0.43 log units below the measured number, within the range that was stated.
By their numbers in this assay, from the lowest: compounds 2, 1 and 3 (each within the scatter of the next).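

In this assay, 1-(carboxymethyl)-1-methylethyl can stand in place of 2-(1H-tetrazol-5-yl)ethyl on a saturated chain carbon bound to a carbonyl carbon, with a number 0.06 log units higher from compound 2 to compound 3 (within the scatter). The comparison with the shorter 1H-tetrazol-5-yl group gives a number 0.02 log units higher from compound 1 to compound 3 (within the scatter), so among these three compounds the five-membered aromatic ring with 4 hetero atoms is not required, and a group with no ring serves as well in this assay. Nothing available accounts for this equivalence.

The compounds shown leave open how an unbranched carboxylic acid chain without the extra methyl groups would read in this assay. They also leave open the outcome of placing a methyl ester or an amine at the end of this chain.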